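The compounds below may be only part of what the source reports. "The series", "measured", "known", "first", "only" and "open" are said of these compounds alone.

Measured in a functional assay on HT-29 cells (Homo sapiens) for inhibition, read by sulforhodamine B assay, with a stated time of 48 h; a higher number here means a weaker inhibitor of growth, a lower number a stronger inhibitor of growth:
compound 1 `CC(C)(C)NCc1c(C(=O)O)nn(-c2ccccc2)c1-c1ccc([N+](=O)[O-])cc1`: > 634000 nM (a limit)
compound 2 `CC(C)(C)NCc1c(C(=O)O)nn(-c2ccc(Cl)cc2)c1-c1ccc(Cl)cc1`: > 599000 nM (a limit)
compound 3 `CC(C)(C)NCc1c(C(=O)O)nn(-c2ccc(Cl)cc2)c1-c1ccccc1`: > 652000 nM (a limit)
Not yet measured: compound 4 `CC(C)(C)NCc1c(C(=O)O)nn(-c2ccc(Cl)cc2)c1-c1ccc([N+](=O)[O-])cc1`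

Compound 3 stands at its limit of > 652000 nM and gives no number. The other two measured compounds also give only limits. The change to compound 4 is nitro in place of hydrogen on an aromatic carbon, with nitro in place of hydrogen on an aromatic carbon, phenyl to 4-nitrophenyl. Among the compounds with values here, the only measured step, a step that the two limits leave unreadable from compound 2 to compound 3, offers no size to carry over. Compound 1 already carries the 4-nitrophenyl and gives only the limit > 634000 nM. Compound 2 likewise gives only the limit > 599000 nM. On these limits, no step beyond the scatter is expected in this assay, in either direction. The expected step is an at least 1.1-fold lower number from compound 3 to compound 4 (0.04 log units; that floor lies within the scatter). Compound 4 is expected to be reported as a limit too. The estimate for compound 4 is 583000 nM, with an expected range from 400000 nM to 650000 nM.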

Compound 4, concentration for 50% growth inhibition: > 583000 nM
Compound 4: no number, only a limit (the forecaster's own chance of this, stated with the estimate: 90%); the middle value sits exactly at the limit.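

Compound 4 gives only a limit, as do compound 1, compound 2 and compound 3, so no step among these compounds can be read. On these data alone, whether nitro, chloro or hydrogen makes any difference to growth inhibition in this assay stays open.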